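The source may hold more compounds than are shown below. What is called first, only, known or untested is meant among the compounds shown, and "the series" means these compounds.

Compound 1 `COc1ccc(Oc2ccc3c(NCCCNCc4cc(F)ccc4OC)ccnc3c2)cc1` gives 14500 nM in a physicochemical assay for solubility, with a stated time of 18 h, at pH 7.4; on this read-out lower numbers stand for lower solubility and higher numbers for higher solubility. Compound 2 `c1ccc(Oc2ccc3c(NCCCNCc4ccco4)ccnc3c2)cc1` gives 14500 nM, and compound 3 `c1ccc(-c2ccc3c(NCCCNCc4ccco4)ccnc3c2)cc1` gives 32000 nM in this assay. Compound 1 therefore stands level with compound 2, the two together holding the lowest of the three numbers, while the number for compound 3 is the highest of the three.

The change from compound 1 to compound 4 `COc1ccc(F)cc1CNCCCNc1ccnc2cc(CCC(C)C)ccc12` is isopentyl in place of 4-methoxyphenoxy on an aromatic carbon. Among the measured compounds shown here, the only measured step that touches a similar region of the shared core is a 2.2-fold higher number from compound 2 to compound 3 (0.34 log units; beyond the scatter), where the group carrying an ether oxygen gave way to a group without one; that step lies beyond the scatter but remains modest in size. For the measured compounds named here, the present change also removes the ether oxygen and its aromatic ring, but brings in an isopentyl chain, a group that no measured pair of compounds covers. With only one modest, loosely related step to lean on, a small rise in this assay is expected, though a shift in either direction within the scatter would be unsurprising. The step from compound 1 to compound 4 is estimated at a 1.4-fold higher number from compound 1 to compound 4 (0.14 log units; within the scatter). Compound 4 is thus expected to give about 20000 nM, within a range from 7000 nM to 60000 nM.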

Compound 4, solubility: 4200 nM
Estimate against measurement, compound 4: 4.8-fold (0.68 log units) above; measured number below the stated range.
By their numbers in this assay, from the lowest: compound 4; then compounds 1 and 2 (each within the scatter of the next); then compound 3.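

In this assay the swap of 4-methoxyphenoxy for isopentyl on this aromatic carbon gives a 3.5-fold lower number from compound 1 to compound 4 (0.54 log units; beyond the scatter) and so shows that a change at this position can also lower the number. Among the compounds shown here, the only earlier step here, phenyl in place of phenoxy, gave a 2.2-fold higher number from compound 2 to compound 3 (0.34 log units; beyond the scatter) and pointed the other way, so removing an oxygen-linked ring group does not on its own fix the direction across these compounds, although the two steps were taken on different side chains and bring in different groups, an aromatic ring in one and an open chain with no ring in the other. No measurement among these compounds accounts for the drop seen with isopentyl.

On these data alone, it remains open whether the fall follows from the loss of a ring at this carbon or from the branched chain itself, which a cyclohexyl group, a straight butyl chain or a longer chain ending in an amine or a carboxylic acid could help to separate. As far as these compounds go, it is also open whether phenyl and isopentyl would give steps of the same direction and size if each were placed on the side chain of the other's series.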